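The compounds below may be only part of what the source reports. "The series", "measured", "known", "first", "only" and "open" are said of these compounds alone.

Of the compounds shown here, three have so far been measured in an ADME assay on isolated protein for inhibition of carbonic anhydrase 4 (Homo sapiens), read by stopped-flow, with a stated time of 15 min; a lower number here means a stronger inhibitor, a higher number a weaker inhibitor. Compound 1, with the structure `Nc1ccccc1S(=O)(=O)[N-][N+](=O)[O-]`, gives 39200 nM. Compound 2, with the structure `NCc1ccc(S(=O)(=O)[N-][N+](=O)[O-])cc1`, gives 3100 nM. Compound 3, with the structure `Nc1cccc(S(=O)(=O)[N-][N+](=O)[O-])c1`, gives 4300 nM. Among these three numbers compound 3 stands second highest: compound 2 lies within the usual scatter of it, so the two cannot be told apart, while compound 1 gives a number that is higher by a margin well beyond the scatter.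

Compound 4, with the structure `CN(C)c1cccc(S(=O)(=O)[N-][N+](=O)[O-])c1`, has not yet been measured in this assay. It differs from compound 3 in one place: dimethylamino in place of amino on an aromatic carbon. For the measured compounds named here, no step between two measured compounds shows what this kind of change does here, so there is no direct guide to the direction.

On this thin basis the expected step is a 1.4-fold higher number from compound 3 to compound 4 (0.14 log units; within the scatter), that is, a small shift toward a higher number that may well stay within the scatter. Compound 4 is therefore expected to give about 6000 nM in this assay, with a plausible range from 2000 nM to 20000 nM.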

Compound 4, inhibition constant: 4500 nM
Compound 4: middle estimate off by 1.3-fold (0.12 log units), on the high side; low and high end bracket the measured number.
By their numbers in this assay, from the lowest: compounds 2, 3 and 4 (each within the scatter of the next); then compound 1.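

In this assay dimethylamino in place of amino on an aromatic carbon gives a 1.0-fold higher number from compound 3 to compound 4 (0.02 log units; within the scatter) and so the two compounds cannot be told apart. For the compounds shown here, this is the first change at this position with a number on both sides, and it shows that this position accepts the swap with no readable shift, even though the hydrogen-bond donor of amino goes and two carbons come in. Nothing measured here gives a reason for this.

As far as these compounds go, whether the number would also hold with a longer chain on the nitrogen, an acetamide or a carboxylic acid at this position stays open. Also open, from the compounds shown here alone, is whether the same swap would leave the number unmoved on the amino of compound 1.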